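Compound 3 and a halogenated counterpart

The source may report more compounds than this note shows. Statements on the series, on what has been measured and on what is new or still open speak of the compounds shown alone.

Values in a functional assay on Caco-2 cells (Homo sapiens) for inhibition, read by MTT assay, with a stated time of 48 h, tested at 10 uM (a higher number here means more inhibition of growth at the concentration tested, a lower number less inhibition of growth), for the measured compounds are these:
Compound 1 `Cc1cc(=O)c2c(O)cc(OCc3ccccc3Br)c([C@H]3CCN(C)C[C@H]3O)c2o1` gives 35%
Compound 2 `Cc1cc(=O)c2c(O)c(CN3CCC(N4CCCCC4)CC3)c(O)c([C@H]3CCN(C)C[C@H]3O)c2o1` gives 31%
Compound 3 `Cc1oc2c([C@H]3CCN(C)C[C@H]3O)c(O)cc(O)c2c(=O)c1C(O)c1ccc([N+](=O)[O-])cc1` gives 5%

Compound 3 is the lowest of the three, and its gaps to compound 2 and to compound 1 both lie beyond the scatter. Compound 4 `Cc1oc2c([C@H]3CCN(C)C[C@H]3O)c(O)cc(O)c2c(=O)c1C(O)c1ccc(F)c(Br)c1` differs from it in one place, with 3-bromo-4-fluorophenyl in place of 4-nitrophenyl on a saturated chain carbon bound to an aromatic carbon and an oxygen on a saturated carbon while the shared core stays the same. Among the compounds with values here, no measured pair shows this exchange, so its size cannot be read from the data. A modest upward step is expected, since compound 3 at 5% leaves much room below the other two values, though the change may stay within the scatter. The estimated change is a number 12 percentage points higher from compound 3 to compound 4 (beyond the scatter) in this assay and remains uncertain. For compound 4 the expected value is 17% with an estimated range from 3% to 40% in this assay when it is tested.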

Compound 4, percent growth inhibition at one concentration: 6%
Compound 4: the middle estimate sits 11 percentage points above what was measured, within the range that was stated.
By their numbers in this assay, from the lowest: compounds 3 and 4 (each within the scatter of the next); then compounds 2 and 1 (each within the scatter of the next).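

In this assay, exchanging 4-nitrophenyl for 3-bromo-4-fluorophenyl on a saturated chain carbon bound to an aromatic carbon and an oxygen on a saturated carbon gives a number 1 percentage points higher from compound 3 to compound 4 (within the scatter). Within the data shown here, this is the first comparison that changes one place only, and it shows that these two substituted phenyl groups cannot be told apart at this position in this read-out, even though the exchange removes the nitro group and brings in bromine and fluorine. Nothing available bears on why the two compounds read alike.

Among these compounds, compound 1 and compound 2 differ from these two in more than one place, so no step to them can be read. On these data alone, it remains open whether an amine such as piperidine or a carboxylic acid at this position, in place of the phenyl ring, would move the number beyond the scatter.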